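The source may hold more compounds than are shown below. What is called first, only, known or untested is meant among the compounds shown, and "the series" means these compounds.

Measured in a functional assay on ECa-109 cells for inhibition, with ECa-109 cell line (Homo sapiens) as the target, read by sulforhodamine B assay; a lower number here means a stronger inhibitor, a higher number a weaker inhibitor:

- compound 1 `COc1ccccc1NC1=CC(=O)c2nc3n(c2C1=O)[C@H]1OC[C@@H](O)[C@H]1OC3`: > 4000 nM, a limit
- compound 2 `CCOc1ccc(NC2=CC(=O)c3nc4n(c3C2=O)[C@H]2OC[C@@H](O)[C@H]2OC4)cc1`: 3210 nM
- compound 3 `O=C1C=C(Nc2ccc(I)cc2)C(=O)c2c1nc1n2[C@H]2OC[C@@H](O)[C@H]2OC1`: not yet measured

Among the measured compounds shown here, compound 2 holds the only actual number in this assay, 3210 nM. The result for compound 1 is a limit and not a number, as the limit of > 4000 nM in this assay, at which 1 of the 2 values shown sits, records.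

The change under study is 4-ethoxyphenyl to 4-iodophenyl, which puts iodo in place of ethoxy on an aromatic carbon, para to a large group: iodo in place of ethoxy on an aromatic carbon.

For the measured compounds named here, only one measured step bears on this change, an at least 1.2-fold lower number from compound 1 to compound 2 (0.09 log units; that floor lies within the scatter), which also alters the aryl group on the amine nitrogen. That step shows nothing beyond the scatter, so it offers no size to carry over, and no step beyond the scatter is expected in this assay. The estimated step is a 1.3-fold lower number from compound 2 to compound 3 (0.11 log units; within the scatter). Compound 3 is expected at 2500 nM, with an estimated range from 800 nM to 6000 nM.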

Compound 3, half-maximal inhibitory concentration: 2300 nM
Estimate against measurement, compound 3: 1.1-fold (0.04 log units) above, within the range that was stated.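

Among the compounds shown here, the step of a 1.4-fold lower number from compound 2 to compound 3 (0.14 log units; within the scatter) is the first in this assay between two actual numbers, and it shows that iodo and ethoxy on this aromatic carbon cannot be told apart in this assay, although iodo has one heavy atom and ethoxy three. The comparison of 4-iodophenyl with 2-methoxyphenyl on the amine nitrogen gives only an at least 1.7-fold lower number from compound 1 to compound 3 (0.24 log units; that floor lies within the scatter), a floor and not a full size. The result for compound 1 is a limit and not a number: the limit of > 4000 nM in this assay, at which 1 of the 3 values shown sits.

From the compounds shown here alone, it remains open whether another group on the same aromatic carbon, such as an amine, a carboxylic acid or a longer alkoxy chain, would give a step beyond the scatter. Going by these compounds, how a plain phenyl on the amine nitrogen would compare also remains open.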